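The source may report more compounds than this note shows. Statements on the series, on what has been measured and on what is new or still open speak of the compounds shown alone.

Measured so far:
compound 1, `O=c1cccnn1CCC(=S)N1CCCC1`: 29.7%
compound 2, `N=C(S)CCCCCCN1N=C(c2ccccc2)CCC1=O`: 68.3%
compound 3, `CC1=NN(CCC(=N)S)C(=O)CC1`: 34.8%

In a functional assay on the whole organism (stomach) for inhibition, with Rattus norvegicus as the target, at a dose of 100 mg/kg by the intraduodenal route (a higher number here means more inhibition at the dose given (going by the name of the read-out), a lower number less inhibition), compound 1 gives the lowest of the three numbers. Compound 3 stands nearest, its value lying within the scatter of that of compound 1, so no order between those two can be read. Within the data shown here, compound 2 stands furthest, its value beyond the scatter above that of compound 1; no single step links the two structures, so only the two values themselves can be compared.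

Compound 4, `O=c1ccc(-c2ccccc2)nn1CCC(=S)N1CCCC1`, differs from compound 1 by phenyl in place of hydrogen on an aromatic carbon. The expected step is a moderate rise, a number 12.3 percentage points higher from compound 1 to compound 4 (beyond the scatter), of roughly the size of the scatter. Compound 4 is therefore estimated to give 42% in this assay, with a range from 20% to 65%.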

Compound 4, a percentage reported as inhibition, in the whole organism at one dose (the size of the read-out at that dose, not a potency): 38.2%
Compound 4: the middle estimate sits 3.8 percentage points above what was measured; the measured number falls inside the stated range.
By their numbers in this assay, from the lowest: compounds 1, 3 and 4 (each within the scatter of the next); then compound 2.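

The step for phenyl in place of hydrogen on this aromatic carbon, next to the ring nitrogen, reads a number 8.5 percentage points higher from compound 1 to compound 4 (within the scatter) in this assay, so no difference between the two compounds can be read at this position. The core of compound 1 thus carries a phenyl here and still gives a number that cannot be told apart from its own. Nothing available bears on why the step has this size.

Going by these compounds, what an amine or a carboxylic acid on this same aromatic carbon would give in this assay remains open. So does whether a methoxy group on the phenyl would carry the number beyond the scatter.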